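This account rests on a few compounds, and the source may have more. Where it says the series, first, only, none or still open, it means among the compounds named here.

Measured in a functional assay on HeLa cells (Homo sapiens) for antiproliferative activity, read by cell counting, with a stated time of 2 days; a lower number here means a stronger inhibitor, a higher number a weaker inhibitor:
compound 1 `COc1ccc(Nc2nc(N)c(C(=O)c3ccc(Cl)cc3)s2)cc1`: 83 nM
compound 2 `COc1ccc(C(=O)c2sc(Nc3ccc(Cl)cc3)nc2N)cc1`: > 10000 nM
compound 3 `COc1ccc(C(=O)c2sc(Nc3ccc(F)cc3)nc2N)cc1`: > 10000 nM

Only compound 1 has a true number, at 83 nM. Compound 2 is reported as > 10000 nM, which is a limit of the assay. Compound 3 is reported as > 10000 nM, also a limit. The series therefore has one number, and the rest sits at the limit of > 10000 nM in this assay, at which 2 of the 3 values shown sit.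

Compound 4 `COc1ccc(Nc2nc(N)c(C(=O)c3cccc(OC)c3)s2)cc1` puts 3-methoxyphenyl in place of 4-chlorophenyl on a carbonyl carbon and leaves the rest of compound 1 unchanged: 3-methoxyphenyl in place of 4-chlorophenyl on a carbonyl carbon.

Going by the values given here, the only measured single-place change is a step that the two limits leave unreadable from compound 2 to compound 3. Among the compounds with values here, it lies elsewhere in the molecule and has no readable size, so no measured step sets a scale for this change. The nearest hint is indirect. Compound 2 also carries a methoxyphenyl on the carbonyl carbon and stands at > 10000 nM, though it differs from compound 4 in more than that one place. A weakening in this assay is therefore expected, of uncertain size and perhaps large.

For compound 4 the expected value is 600 nM. The estimated range for compound 4 runs from 80 nM to 6000 nM. This estimate amounts to an expected 7.2-fold higher number from compound 1 to compound 4 (0.86 log units; beyond the scatter).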

Compound 4, half-maximal inhibitory concentration: 37 nM
Compound 4: the middle estimate sits 16-fold (1.21 log units) above what was measured; the whole stated range lies above it.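

In this assay, going by these compounds alone, putting 3-methoxyphenyl in place of 4-chlorophenyl on the carbonyl carbon gives a 2.2-fold lower number from compound 1 to compound 4 (0.35 log units; beyond the scatter), which is the first step with a readable size and sets a first scale for changes at this place. It shows that the 4-chlorophenyl is not needed for activity in this assay: a group that carries oxygen rather than chlorine, and that counts one hydrogen-bond acceptor where the group it replaces counts none, keeps the number in the same low range and moves it modestly lower. The values shown include no measured property that would explain this step, so the gain stays an observation without a stated cause.

This single step changes both the substituent and its ring position, so the compounds shown cannot tell how much of the step belongs to the methoxy group itself and how much to where it sits. They also leave open how an unsubstituted phenyl, or a phenyl bearing an amine or a carboxylic acid, would fare on this carbonyl carbon.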